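A few compounds are considered here, and "the series" means these few. Any claim that something is new, unique, unknown or untested is made for them only; others in the source may bear on it.

Of the compounds shown here, two with a shared core have been tested in a functional assay on A-431 cells (Homo sapiens), tested at 0.1 uM; a lower number here means less inhibition, a higher number more inhibition at the concentration tested (going by the name of the read-out). Compound 1 `COc1ccc(Nc2n[nH]c(-c3cccnc3Nc3cc(OC)cc(OC)c3)n2)cc1` gives 68% there, the lower of the two numbers. Compound 2 `COc1cc(Nc2ncccc2-c2n[nH]c(Nc3ccc4c(c3)OCCO4)n2)cc(OC)c1` gives 83% in this assay, higher than compound 1 by more than the usual scatter. Compound 3 `COc1cccc(CNc2n[nH]c(-c3cccnc3Nc3cc(OC)cc(OC)c3)n2)c1` has not yet been measured; it differs from compound 1 in one place: 3-methoxybenzyl in place of 4-methoxyphenyl on a nitrogen on an aromatic ring. Going by the values given here, no measured pair shows a change of this kind, so nothing sets its size. Compound 3 is expected to give 55% in this assay, within 25% to 85%. That expectation means a step of a number 13 percentage points lower from compound 1 to compound 3 (beyond the scatter), a modest drop that may not exceed the scatter.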

Compound 3, a percentage reported as inhibition, at one concentration (the size of the read-out at that concentration, not a potency): 71%
Compound 3: middle estimate off by 16 percentage points, on the low side; measured number inside the range.
By their numbers in this assay, from the lowest: compounds 1 and 3 (each within the scatter of the next); then compound 2.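

In this assay, putting 3-methoxybenzyl in place of 4-methoxyphenyl on a nitrogen on an aromatic ring gives a step of a number 3 percentage points higher from compound 1 to compound 3 (within the scatter). Going by these compounds alone, this is the first measured step at this position, and it shows that this exchange of groups leaves the read-out within the scatter at the concentration tested. Nothing measured here explains this result.

The change alters two things at once: it adds a carbon link and it moves the methoxy group. 4-Methoxybenzyl and 3-methoxyphenyl would show separately what each alteration does.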